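This account rests on a few compounds, and the source may have more. Where it says the series, first, only, none or still open, it means among the compounds named here.

In an assay on HEK293 cells for inhibition of Voltage-dependent T-type calcium channel subunit alpha-1G (Homo sapiens), read by patch clamp (on this read-out higher numbers stand for weaker inhibition and lower numbers for stronger inhibition), compound 1 `CCCc1nc(-c2ccccc2)c(CNCCCN2CCN(c3cccc(C)c3)CC2)o1` gives 1190 nM, the lowest of the three numbers shown. Compound 2 `CCCc1nc(-c2ccccc2)c(CNCCN2CCN(c3ccccc3C)CC2)o1` gives 4300 nM and compound 3 `CCCc1nc(-c2ccccc2)c(CNCCN2CCN(c3ccc(F)cc3)CC2)o1` gives 7080 nM; compound 1 differs from both in more than one place, so their gaps cannot be traced to a single change. Compound 4 `CCCc1nc(-c2ccccc2)c(CNCCCN2CCN(c3ccc(C)c(C)c3)CC2)o1` is the unmeasured neighbour of compound 1, with one change: methyl in place of hydrogen on an aromatic carbon. Going by the values given here, the only single-place step available swaps one aryl group for another, a 1.6-fold higher number from compound 2 to compound 3 (0.22 log units; within the scatter), and stays within the scatter. That step and the change at hand are only loosely alike, so no step beyond the scatter is expected in this assay, as a 1.1-fold higher number from compound 1 to compound 4 (0.04 log units; within the scatter). Compound 4 is estimated at 1300 nM, within 500 nM to 3500 nM.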

Compound 4, half-maximal inhibitory concentration: 3020 nM
For compound 4 the middle estimate is 2.3-fold (0.37 log units) below the measured one; the range from low to high includes it.
By their numbers in this assay, from the lowest: compound 1; then compounds 4, 2 and 3 (each within the scatter of the next, the first and the last beyond it).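

Adding a second methyl group to compound 1, which turns 3-methylphenyl into 3,4-dimethylphenyl, gives a 2.5-fold higher number from compound 1 to compound 4 (0.40 log units; beyond the scatter) in this assay. Going by these compounds alone, this is the first single-place change in the set to go beyond the scatter, so this aromatic carbon, para to a large group and ortho to a methyl group, is not indifferent to one added carbon. Nothing measured here gives a reason for the shift. The compounds shown leave open whether a methoxy group or a chlorine atom on this carbon would give a similar step, and whether the step would persist without the neighbouring methyl group.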